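Trimming the Distal Phenyl Group from Compound 1

The source may hold more compounds than are shown below. What is called first, only, known or untested is meant among the compounds shown, and "the series" means these compounds.

Compound 1 `O[C@@H]1[C@@H](O)CN[C@H]1c1ccc(-c2ccccc2)cc1` stands lowest of the two compounds examined in an assay on isolated protein for inhibition of alpha-mannosidase (Canavalia ensiformis), read by spectrophotometry, tested at 1000 uM; a lower number here means less inhibition, a higher number more inhibition at the concentration tested (going by the name of the read-out). In this assay compound 1 gives 0%, while compound 2 `O[C@H]1[C@H](CCCc2ccccc2)NC[C@@H]1O` gives 11.5%, a gap that lies beyond the usual scatter of repeated measurements. Compound 3 `O[C@@H]1[C@@H](O)CN[C@H]1c1ccccc1` has not yet been measured. It differs from compound 1 in a single place: hydrogen in place of phenyl on an aromatic carbon. Among the measured compounds shown here, no pair of measured compounds that differ in one place is available, so the size of such a step cannot be read from the numbers at hand. Because compound 1 already gives the lowest number seen in this assay with 0%, the step of a number 3 percentage points higher from compound 1 to compound 3 (within the scatter) is expected to be small, most likely within the scatter, and in the upward direction if anywhere. Compound 3 is therefore estimated to give 3%, with a range from 0% to 12%.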

Compound 3, a percentage reported as inhibition, at one concentration (the size of the read-out at that concentration, not a potency): 2%
For compound 3 the middle estimate is 1 percentage points above the measured one, within the range that was stated.
By their numbers in this assay, from the lowest: compounds 1, 3 and 2 (each within the scatter of the next, the first and the last beyond it).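

Hydrogen in place of phenyl on an aromatic carbon gives a number 2 percentage points higher from compound 1 to compound 3 (within the scatter) in this assay and this is the first step in the series that can be read between two compounds differing in one place. At this position, the phenyl can therefore go without a change that this assay can separate from scatter. With compound 1 at 0% and compound 3 at 2% both numbers lie close to the bottom of the read-out, so the step shows no gain from either group at the concentration tested, and nothing available accounts for this.

From the compounds shown here alone, whether an amine, a carboxylic acid or a longer chain on this aromatic carbon would raise the number remains open. So does whether changes elsewhere on the shared core would matter more than this one.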